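A few compounds are considered here, and "the series" means these few. Any claim that something is new, unique, unknown or untested is made for them only; others in the source may bear on it.

Measured compounds in an ADME assay (liver) for pharmacokinetics, with Liver microsome (Rattus norvegicus) as the target, using microsomes; on this read-out higher numbers stand for a longer-lived compound and lower numbers for a shorter-lived compound:

- compound 1 `CCCOC(=O)/C=C/c1ccc(NC(=O)C2(NC(=O)c3ccc4c(C5CCCC5)c(-c5ncc(Cl)cn5)n(C)c4c3)CCC2)cc1OCC`: 0.35 h
- compound 2 `CCOc1cc(NC(=O)C2(NC(=O)c3ccc4c(C5CCCC5)c(-c5ncc(Cl)cn5)n(C)c4c3)CCC2)ccc1/C=C/C(=O)OCC(Cl)(Cl)Cl`: 0.233 h
- compound 3 `CCOc1cc(NC(=O)C2(NC(=O)c3ccc4c(C5CCCC5)c(-c5ncc(Cl)cn5)n(C)c4c3)CCC2)ccc1/C=C/C(=O)OCC(=O)OCc1ccc(Cl)cc1`: 11.4 h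

Compound 1 stands second highest of the three numbers; the nearest is compound 2 and the furthest compound 3. Of the two measured steps from compound 1, a 1.5-fold lower number from compound 1 to compound 2 (0.18 log units; within the scatter), while a 33-fold higher number from compound 1 to compound 3 (1.51 log units; beyond the scatter). The third step, a 49-fold higher number from compound 2 to compound 3 (1.69 log units; beyond the scatter), points the same way as the second.

The unmeasured compound 4 `CCOc1cc(NC(=O)C2(NC(=O)c3ccc4c(C5CCCC5)c(-c5ncc(Cl)cn5)n(C)c4c3)CCC2)ccc1/C=C/C(=O)OCC(N)=O` differs from compound 1 as follows: carbamoyl in place of ethyl on a saturated chain carbon bound to an oxygen next to a carbonyl group. For the measured compounds named here, the carbamoyl group entering here is neither the trichloromethyl of compound 2 nor the ((4-chlorobenzyl)oxy)carbonyl of compound 3, so no measured step matches it directly. The small step to compound 2 shows that not every change at this carbon moves this assay, and the large step to compound 3 shows that one such change did. Going by the values given here, with no closer analogue, a step near the scatter is expected: a 1.7-fold higher number from compound 1 to compound 4 (0.23 log units; within the scatter).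

Compound 4 is therefore estimated at 0.6 h in this assay, with a range of 0.2 h to 2.5 h.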

Compound 4, half-life: 0.383 h
Beside the measured number, compound 4's estimate is 1.6-fold (0.19 log units) above it; the measured number falls inside the stated range.
By their numbers in this assay, from the lowest: compounds 2, 1 and 4 (each within the scatter of the next); then compound 3.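

In this assay, carbamoyl on the saturated chain carbon bound to an oxygen next to a carbonyl group reads no differently from ethyl or trichloromethyl: a 1.1-fold higher number from compound 1 to compound 4 (0.04 log units; within the scatter) and a 1.6-fold higher number from compound 2 to compound 4 (0.22 log units; within the scatter) are both small steps. A carbonyl group on this carbon therefore does not by itself carry the high number of compound 3, as a 30-fold lower number from compound 3 to compound 4 (1.47 log units; beyond the scatter) is a large step with only amino in place of (4-chlorobenzyl)oxy on a carbonyl carbon. Nothing available explains this gap in half-life.

From the compounds shown here alone, the high number rests on compound 3 alone, so it remains open which part of (4-chlorobenzyl)oxy matters. A benzyloxy or methoxy on that carbonyl carbon, or a carboxylic acid there, would separate the chlorine, the ring and the ester.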